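The compounds below may be only part of what the source reports. "The series", "measured", "known", "first", "only" and "open" are said of these compounds alone.

In an ADME assay on Vero cells (Chlorocebus sabaeus) for inhibition, read by sulforhodamine B assay, with a stated time of 48 h; on this read-out lower numbers stand for stronger inhibition of growth and higher numbers for weaker inhibition of growth:

compound 1 `CC1=CC[C@H](C(C)(C)NC(=S)N/N=C/c2ccc(O)cc2)CC1`, > 100000 nM
compound 2 `CC1=CC[C@H](C(C)(C)NC(=S)N/N=C/c2ccc(N(C)C)cc2)CC1`, 75600 nM
compound 3 `COc1cc(/C=N/NC(=S)NC(C)(C)[C@H]2CC=C(C)CC2)ccc1O`, 19700 nM

Compound 1 sits at the limit of > 100000 nM in this assay, at which 1 of the 3 values shown sits; for it only a limit is known, not a number. Compound 2 and compound 3 each give a number, and compound 3 has the lowest number among the three.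

Compound 4 `CC1=CC[C@H](C(C)(C)NC(=S)N/N=C/c2ccco2)CC1` differs from compound 1 by furan-2-yl in place of 4-hydroxyphenyl on a carbon with a double bond to nitrogen.

Two measured steps leave compound 1, both on the same aromatic ring that is exchanged here: an at least 1.3-fold lower number from compound 1 to compound 2 (0.12 log units; that floor lies within the scatter) and an at least 5.0-fold lower number from compound 1 to compound 3 (0.70 log units; beyond the scatter). Neither step raises the number. In the step to compound 2 the hydroxy leaves, as it also does in the step to compound 4; the step to compound 3 keeps the hydroxy and adds a methoxy, so it is the less similar of the two. Neither step removes the six-membered ring itself, so the exchange for furan-2-yl is not covered by a close precedent.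

Given that both known steps from compound 1 go toward lower or unchanged numbers, a modest step toward a lower number in this assay is expected, an at least 1.4-fold lower number from compound 1 to compound 4 (0.15 log units; that floor lies within the scatter), while an outcome at the limit remains well possible. Compound 4 is thus estimated at 70000 nM, with a range from 20000 nM to 150000 nM.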

Compound 4, concentration for 50% growth inhibition: 5100 nM
For compound 4 the middle estimate is 14-fold (1.14 log units) above the measured one, and the stated range ends above it.
By their numbers in this assay, from the lowest: compound 4; then compound 3; then compound 2. At a limit, above all of these: compound 1.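

In this assay, going by these compounds alone, furan-2-yl in place of 4-hydroxyphenyl gives an at least 19-fold lower number from compound 1 to compound 4 (1.29 log units; beyond the scatter) and so shows that, at this carbon with a double bond to nitrogen, exchanging the whole aromatic ring can move the number substantially, which the earlier steps on that ring could not show. The floor of this step is the largest of the three steps leaving compound 1, yet the hydroxy alone does not give a consistent reading: it leaves in the step to compound 2, whose floor lies within the scatter, and it stays in the step to compound 3, whose floor lies beyond it. From the compounds shown here alone, the true size of the new step remains unknown, because compound 1 carries only a limit and not a number: the limit of > 100000 nM in this assay, at which 1 of the 4 values shown sits.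

The compounds shown leave open whether the lower number of compound 4 belongs to the five-membered ring, to its ring oxygen, or simply to the absence of the hydroxy. Thiophen-2-yl or unsubstituted phenyl on this carbon would separate these readings.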